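Fluoro for Methoxy on the Sulfonyl Aryl of Compound 2

The source may report more compounds than this note shows. Statements on the series, on what has been measured and on what is new or still open speak of the compounds shown alone.

Compound 2 `COc1ccc(S(=O)(=O)c2nc3ccccc3nc2Nc2cc(OC)c(OC)c(OC)c2)cc1` stands weakest among the numbers shown, though only as a limit: in a functional assay on HCT-116 cells (Homo sapiens) for cytotoxicity, read by MTT assay, with a stated time of 72 h (a lower number here means a stronger inhibitor, a higher number a weaker inhibitor), compound 2 reaches only > 50000 nM, a limit of the assay rather than a number. Compound 1 `COc1ccc(S(=O)(=O)c2nc3ccccc3nc2Nc2cc(OC)cc(OC)c2)cc1` gives 13400 nM in this assay, and the step of an at least 3.7-fold higher number from compound 1 to compound 2 (0.57 log units; beyond the scatter) lies beyond the scatter. Compound 3 `COc1cc(Nc2nc3ccccc3nc2S(=O)(=O)c2ccc(F)cc2)cc(OC)c1OC` differs from compound 2 by fluoro in place of methoxy on an aromatic carbon. Among the measured compounds shown here, no measured step touches this change; the single recorded step, from compound 1 to compound 2, concerns a different substitution, a methoxy in place of hydrogen, and so gives no guide to the direction here. Because compound 2 already sits at the limit (the limit of > 50000 nM in this assay, at which 1 of the 2 values shown sits), the expected step of an at least 1.1-fold lower number from compound 2 to compound 3 (0.04 log units; that floor lies within the scatter) cannot be sized from the data and is taken as none beyond the scatter. Compound 3 is therefore estimated at 45000 nM, within a range of 12000 nM to 150000 nM, with a fair chance that it again returns only a limit.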

Compound 3, half-maximal inhibitory concentration: 3110 nM
The estimate for compound 3 lay 14-fold (1.16 log units) above the measured number; the whole stated range lies above it.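

The result shows that the group on the (4-methoxyphenyl)sulfonyl side of the molecule bears strongly on the read-out in this assay, a point compounds 1 and 2 could not show, as both carry the same 4-methoxyphenyl. Going from 4-methoxyphenyl to 4-fluorophenyl gives an at least 16-fold lower number from compound 2 to compound 3 (1.20 log units; beyond the scatter), and with the rest of the structure unchanged, this one swap carries the whole step. That figure is a floor and not the full size of the step, as compound 2 gives only a limit: the limit of > 50000 nM in this assay, at which 1 of the 3 values shown sits.

The compounds shown leave open whether the gain belongs to fluoro itself or to the loss of methoxy, and how hydrogen, chloro or an amine would fare at this position. They also leave open whether the methoxy step from compound 1 to compound 2 would hold with 4-fluorophenyl in place.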